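A few compounds are considered here, and "the series" means these few. Any claim that something is new, unique, unknown or untested is made for them only; others in the source may bear on it.

Values in a physicochemical assay for solubility, using the shake flask method, in simulated intestinal fluid, measured as kinetic solubility, with a stated time of 2 h, at 25 degrees C, at pH 6.5; on this read-out higher numbers stand for higher solubility and lower numbers for lower solubility:
- Compound 1 `Cc1noc(-c2nc(C)c3c(c2N)C(=O)N(Cc2ccc(C(F)(F)F)cc2)C3=O)n1`: < 5000 nM, a limit
- Compound 2 `Cc1noc(-c2nc(C)c3c(c2N)C(=O)N(Cc2ccc(S(C)(=O)=O)cc2)C3=O)n1`: < 5000 nM, a limit
- Compound 3 `Cc1noc(-c2nc(C)c3c(c2N)C(=O)N(Cc2ccc(N(C)C)cc2)C3=O)n1`: 7400 nM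

Of the three, only compound 3 has a number; the other two values are limits, as the limit of < 5000 nM in this assay, at which 2 of the 3 values shown sit, records. The unmeasured compound 4 `Cc1noc(-c2nc(C)c3c(c2N)C(=O)N(Cc2ccc(N4CCCC4=O)cc2)C3=O)n1` carries 2-oxopyrrolidin-1-yl in place of dimethylamino on an aromatic carbon. Among the measured compounds shown here, the steps that bear on this change are an at least 1.4-fold higher number from compound 1 to compound 3 (0.17 log units; that floor lies within the scatter) and an at least 1.4-fold higher number from compound 2 to compound 3 (0.17 log units; that floor lies within the scatter). Both are floors, and neither involves 2-oxopyrrolidin-1-yl, so they set no size for this change. No step beyond the scatter is therefore expected in this assay, in either direction. The expected step is a 1.6-fold lower number from compound 3 to compound 4 (0.22 log units; within the scatter). For compound 4 the estimate is 4500 nM, with an expected range from 1800 nM to 9000 nM.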

Compound 4, solubility: < 5000 nM
Compound 4 gave a limit, no number (the forecaster's own chance of this, stated with the estimate: 55%); the middle value lies beyond the limit too.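

With 2-oxopyrrolidin-1-yl in place of dimethylamino, this assay shows an at least 1.4-fold lower number from compound 3 to compound 4 (0.17 log units; that floor lies within the scatter). The steps from compound 1 to compound 4 and from compound 2 to compound 4 cannot be read. Of the four groups on this aromatic carbon, only dimethylamino gives a number, while trifluoromethyl, methylsulfonyl and 2-oxopyrrolidin-1-yl all share one limit: the limit of < 5000 nM in this assay, at which 3 of the 4 values shown sit.

The compounds shown leave open whether compound 1, compound 2 and compound 4 differ from one another at all. They also leave open whether another amine, such as piperidine or morpholine, would give a number at this place.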